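Replacing 1,3-benzothiazol-2-yl with chloro in the series

This account rests on a few compounds, and the source may have more. Where it says the series, first, only, none or still open, it means among the compounds named here.

Three compounds have been taken through an ADME assay on HEK293 cells (Homo sapiens) for cytotoxicity, with a stated time of 72 h (a lower number here means that less compound is needed, a higher number that more compound is needed for the effect), so far, and each returns a limit rather than a number. Compound 1 (`O=C(O)COc1cc(Cl)c(C(=O)Nc2cccc(-c3nc4ccccc4s3)c2)cc1[N+](=O)[O-]`) gives > 25000 nM as its limit. Compound 3 (`COC(=O)C1CCN(c2cc(Cl)c(C(=O)Nc3cc(-c4nc5ccccc5s4)ccc3OC)cc2[N+](=O)[O-])CC1`) gives > 25000 nM as its limit. Compound 2 (`O=C(Nc1ccc(-c2nc3ccccc3s2)cc1)c1cc([N+](=O)[O-])ccc1Cl`) gives > 27000 nM as its limit. Compound 2 is the only one at the limit of > 27000 nM in this assay, at which 1 of the 3 values shown sits, and, with limits alone on hand, no order among the three can be read. Among the compounds with values here, no pair of measured compounds differs in a single place, so the series offers no measured step to lean on.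

Compound 4 (`O=C(Nc1ccc(Cl)cc1)c1cc([N+](=O)[O-])ccc1Cl`) departs from compound 2 by one change: chloro in place of 1,3-benzothiazol-2-yl on an aromatic carbon with chloro in place of 1,3-benzothiazol-2-yl on an aromatic carbon. The expectation for compound 4 rests on compound 2 and its limit of > 27000 nM as the nearest anchor. None of the three compounds gives a numerical read-out in this assay so no step beyond the usual scatter is expected, and another limit is the most likely report. The estimated a number no higher from compound 2 to compound 4 (the limit leaves the size open) therefore stays within the scatter. For compound 4 the estimate is 27000 nM with an expected range from 12000 nM to 50000 nM as the likely span.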

Compound 4, half-maximal effective concentration: > 27000 nM
Compound 4 gave a limit, no number; the forecaster's own chance of this, stated with the estimate: 80%; the middle value lies on the limit itself.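

In this assay compound 4 gives > 27000 nM, a limit. Compound 2 gives > 27000 nM, also a limit. With only these two limits, no step can be read between compound 2 and compound 4. The compounds shown leave open where any of the four would give a number in this assay, and whether chloro in place of 1,3-benzothiazol-2-yl would alter it.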